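Taking the hydroxymethyl off compound 2

The compounds below may be only part of what the source reports. "The series", "measured", "known", "first", "only" and "open" are said of these compounds alone.

In a physicochemical assay for solubility, read by LC-MS, in phosphate buffer, with a stated time of 24 h, at pH 7.4 (on this read-out higher numbers stand for higher solubility and lower numbers for lower solubility), compound 2 `Cc1nc(CO)ccc1-c1cnc(NCc2c(F)ccc3c2CCO3)c2cn[nH]c(=O)c12` gives 3000 nM. Compound 1 `O=C1c2ccccc2CN1c1cnc(NCc2c(F)ccc3c2CCO3)n2cnnc12` gives 4000 nM, within the usual scatter of compound 2, while compound 3 `CN(C)Cc1ccc2c(c1)CN(c1cnc(NCc3c(F)ccc4c3CCO4)n3cnnc13)C2=O` gives 12000 nM, a higher number beyond that scatter.

The unmeasured compound 4 `Cc1ncccc1-c1cnc(NCc2c(F)ccc3c2CCO3)c2cn[nH]c(=O)c12` differs from compound 2 in one place: hydrogen in place of hydroxymethyl on an aromatic carbon. Put simply, hydrogen stands in place of hydroxymethyl on an aromatic carbon next to the ring nitrogen, so 6-(hydroxymethyl)-2-methylpyridin-3-yl becomes 2-methylpyridin-3-yl.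

Going by the values given here, only one measured step offers any guide, and it involves another group on another core, so it bears only loosely on this change. With a group leaving here rather than entering as in a 3.0-fold higher number from compound 1 to compound 3 (0.48 log units; beyond the scatter), a small move toward a lower number is expected, one that may not clear the scatter. The expected change is a 2.0-fold lower number from compound 2 to compound 4 (0.30 log units; within the scatter). Compound 4 is estimated at 1500 nM, with an expected range of 500 nM to 4000 nM.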

Compound 4, solubility: < 2000 nM
Compound 4: a limit, no number; the forecaster's own chance of this, stated with the estimate: 3%; the middle value is on the limit's open side.
By their numbers in this assay, from the lowest: compounds 2 and 1 (each within the scatter of the next); then compound 3. At a limit, below all of these: compound 4.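

Hydrogen in place of hydroxymethyl gives the first reading at this position, the aromatic carbon next to the ring nitrogen: an at least 1.5-fold lower number from compound 2 to compound 4 (0.17 log units; that floor lies within the scatter). Going by these compounds alone, none of the earlier compounds changes anything here, and the only earlier step adds a group on a different core. Compound 4 has no number, only a limit of the assay, so this step gives a floor and not a size: the limit of < 2000 nM in this assay, at which 1 of the 4 values shown sits.

On these data alone, the true distance between compound 2 and compound 4 remains open, and that floor does not settle whether it goes beyond the usual scatter. Also open, as far as these compounds go, is what other groups on this same carbon would give, such as a carboxylic acid, a primary amine or a longer chain like hydroxyethyl.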